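Swapping Phenyl for Thiophene on a Methylamino Nucleoside Core

This account rests on a few compounds, and the source may have more. Where it says the series, first, only, none or still open, it means among the compounds named here.

Measured so far:
compound 1 `COc1ncnc2c1c(-c1cccs1)cn2[C@@H]1O[C@H](CO)[C@@H](O)[C@H]1O` — 90 nM
compound 2 `COc1ncnc2c1c(-c1ccccc1)cn2[C@@H]1O[C@H](CO)[C@@H](O)[C@H]1O` — > 20000 nM
compound 3 `CNc1ncnc2c1c(-c1ccccc1)cn2[C@@H]1O[C@H](CO)[C@@H](O)[C@H]1O` — > 20000 nM

All three were tested in a functional assay on CCRF-CEM cells (Homo sapiens), read by MTT assay, with a stated time of 72 h; on this read-out lower numbers stand for stronger inhibition and higher numbers for weaker inhibition. Compound 1 gives 90 nM in this assay. For compound 2 the result is only a limit of the assay, > 20000 nM. For compound 3 the result is likewise a limit, > 20000 nM. Two of the three values therefore sit at the same limit (the limit of > 20000 nM in this assay, at which 2 of the 3 values shown sit).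

Compounds 1 and 2 share a core and differ in one place: thiophen-2-yl in place of phenyl on an aromatic carbon. This change gave an at least 220-fold lower number from compound 2 to compound 1 (2.34 log units; beyond the scatter). Compounds 2 and 3 differ in their cores: methylamino in place of methoxy on an aromatic carbon. Because both values are limits, this step is a step that the two limits leave unreadable from compound 2 to compound 3.

Compound 4 `CNc1ncnc2c1c(-c1cccs1)cn2[C@@H]1O[C@H](CO)[C@@H](O)[C@H]1O` has not been measured yet. It differs from compound 3 by thiophen-2-yl in place of phenyl on an aromatic carbon, which is the same change as from compound 2 to compound 1, at the same place. Since the step from compound 2 to compound 1 was large but compound 3 carries a different core and its own value is only a limit, the size of the step to compound 4 cannot be read from the data with any confidence. The step from compound 3 to compound 4 is expected to be an at least 33-fold lower number from compound 3 to compound 4 (1.52 log units; beyond the scatter). Compound 4 is therefore estimated to give 600 nM in this assay, with a wide range from 60 nM to 20000 nM.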

Compound 4, half-maximal inhibitory concentration: > 20000 nM
Compound 4 gave a limit, no number (the forecaster's own chance of this, stated with the estimate: 25%); middle value at least 33-fold (1.52 log units) from the limit.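

In this assay compound 4 gives > 20000 nM, which is a limit of the assay and not a number. With thiophen-2-yl kept in place, methylamino in place of methoxy gives an at least 220-fold higher number from compound 1 to compound 4 (2.34 log units; beyond the scatter), so among these four compounds the low number of compound 1 depends on the methoxy core as well as on the thiophen-2-yl group, and the large gain from the swap on that core does not visibly carry over to the methylamino core. This does not show that the swap does nothing on the methylamino core: the step from compound 3 to compound 4 and the step from compound 2 to compound 3 cannot be read, and any smaller change would stay hidden at the limit these compounds share: the limit of > 20000 nM in this assay, at which 3 of the 4 values shown sit.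

The compounds shown leave open whether the low number of compound 1 needs the methoxy group itself, or whether an ethoxy group or a plain amino group in its place, with thiophen-2-yl kept, would also give a low number. They also leave open whether furan-2-yl in place of thiophen-2-yl on the core of compound 1 would keep that low number.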